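Para Substituent Swap on a Dienone: Methoxy to Methyl

The compounds below may be only part of what the source reports. "The series", "measured", "known", "first", "only" and "open" are said of these compounds alone.

Measured compounds in a functional assay on PC-3 cells (Homo sapiens) for cytotoxicity, read by sulforhodamine B assay, with a stated time of 48 h; a lower number here means a stronger inhibitor, a higher number a weaker inhibitor:
compound 1, `CC1=C(/C=C/C(=O)/C=C/c2ccc(C#N)cc2)C(C)(C)CCC1`, 11900 nM
compound 2, `COc1ccc(/C=C/C(=O)/C=C/C2=C(C)CCCC2(C)C)cc1`, 58700 nM

Compound 2 stands at the highest number of the two in this assay; its nearest neighbour is compound 1, reached by a 4.9-fold higher number from compound 1 to compound 2 (0.69 log units; beyond the scatter). Compound 3, `CC1=C(/C=C/C(=O)/C=C/c2ccc(C)cc2)C(C)(C)CCC1`, is not yet measured. It differs from compound 2 by methyl in place of methoxy on an aromatic carbon. Among the measured compounds shown here, the only step on record, a 4.9-fold higher number from compound 1 to compound 2 (0.69 log units; beyond the scatter), concerns the same position but a different pair of groups, so it bears on this change only loosely: it shows that altering this substituent can move the number beyond the scatter. For the measured compounds named here, nothing among the measured compounds tells the direction for methyl. Compound 3 is therefore expected to give roughly 35000 nM, within a wide range of 12000 nM to 100000 nM. This estimate means a step of a 1.7-fold lower number from compound 2 to compound 3 (0.22 log units; within the scatter), which need not lie beyond the scatter.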

Compound 3, half-maximal inhibitory concentration: 21500 nM
Beside the measured number, compound 3's estimate is 1.6-fold (0.21 log units) above it; low and high end bracket the measured number.
By their numbers in this assay, from the lowest: compounds 1 and 3 (each within the scatter of the next); then compound 2.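

Among the compounds shown here, with methyl in place of methoxy, the number in this assay moves beyond the scatter (a 2.7-fold lower number from compound 2 to compound 3 (0.44 log units; beyond the scatter)), which gives the direction that the earlier compounds could not tell for this change. Methyl and cyano, by contrast, cannot be told apart at this place on the ring (a 1.8-fold higher number from compound 1 to compound 3 (0.26 log units; within the scatter)), so among these three groups only methoxy stands apart, with the highest number. Nothing available explains why the number moves with this swap.

The compounds shown leave open how other groups at this place would read, such as an amine, a carboxylic acid or a chlorine atom, and whether a longer chain such as ethoxy would read like methoxy. They also leave open whether the same grouping of methyl, cyano and methoxy would hold on a different core.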